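Glucagon receptor series: amide replacement at the benzamide carbonyl

The source may report more compounds than this note shows. Statements on the series, on what has been measured and on what is new or still open speak of the compounds shown alone.

Of the compounds shown here, two carry numbers so far. Compound 1 `O=C(O)CCNC(=O)c1ccc(CN(C(=O)Nc2ccc(OC(F)(F)F)cc2)C2CCC3(CC2)OCCO3)cc1` gives 1210 nM in an in vitro assay on BHK cells for inhibition of Glucagon receptor (Homo sapiens); a higher number here means a weaker inhibitor, a lower number a stronger inhibitor. Compound 2 `CC(C)(C)C1CCC(N(Cc2ccc(C(=O)N3CCCC(C(=O)O)C3)cc2)C(=O)Nc2ccc(OC(F)(F)F)cc2)CC1` gives 1000 nM in this assay, the lowest of the two numbers, with compound 1 as its nearest neighbour at a gap that stays within the scatter; no order between the two is claimed.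

Compound 3 `CC(C)(CC(=O)O)NC(=O)c1ccc(CN(C(=O)Nc2ccc(OC(F)(F)F)cc2)C2CCC(C(C)(C)C)CC2)cc1` differs from compound 2 in one place: (1-(carboxymethyl)-1-methylethyl)amino in place of 3-carboxypiperidin-1-yl on a carbonyl carbon. Within the data shown here, no measured pair shows this change, so its effect is unknown. The step from compound 2 to compound 3 is expected to be small, a 1.1-fold lower number from compound 2 to compound 3 (0.05 log units; within the scatter), with no clear direction beyond the scatter. Compound 3 is therefore estimated at 900 nM in this assay, within a range from 400 nM to 2200 nM.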

Compound 3, half-maximal inhibitory concentration: > 10000 nM
Compound 3 was reported as a limit; the forecaster's own chance of this, stated with the estimate: 5%; middle value at least 11-fold (1.04 log units) from the limit.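

Among these compounds, this position is the first place where a single change reads beyond the scatter: on the carbonyl carbon, (1-(carboxymethyl)-1-methylethyl)amino in place of 3-carboxypiperidin-1-yl gives an at least 10-fold higher number from compound 2 to compound 3 (1.00 log units; beyond the scatter) in this assay. Compound 3 stands at > 10000 nM, which is a limit of the assay and not a number, so the step gives only a minimum size: the limit of > 10000 nM in this assay, at which 1 of the 3 values shown sits. Compounds 1 and 2 differ in more than one place and gave no reading of this position, whereas this pair shows that the two groups are not interchangeable here.

The pair cannot separate the loss of the ring from the gem-dimethyl branching or the amide hydrogen. An unbranched 3-carboxypropylamino group or a 4-carboxypiperidin-1-yl group on the same carbonyl would bear on that question.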